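Compound 3: bromo for fluoro on the 4-aryl position

The source may hold more compounds than are shown below. What is called first, only, known or untested is meant among the compounds shown, and "the series" means these compounds.

Values in a functional assay on HepG2 cells (Homo sapiens) for cytotoxicity, read by MTT assay, with a stated time of 72 h; on this read-out higher numbers stand for weaker inhibition and lower numbers for stronger inhibition
- compound 1 `CNC(=O)c1cc(Oc2ccc(C3=NNC(c4ccc(OC)cc4)C3)cc2)ccn1` gives 9640 nM
- compound 2 `CNC(=O)c1cc(Oc2ccc(C3=NNC(c4ccc(F)cc4)C3)cc2)ccn1` gives 5280 nM

Going by the values given here, only two measurements are available so far, and compound 2 cannot be separated from compound 1 on them: the two values lie within the scatter of each other. The next compound to read is compound 3 `CNC(=O)c1cc(Oc2ccc(C3=NNC(c4ccc(Br)cc4)C3)cc2)ccn1`, which carries bromo in place of fluoro on an aromatic carbon. The change sits on an aromatic carbon of a six-membered aromatic ring of carbon only, para to a large group, and reads as 4-fluorophenyl to 4-bromophenyl.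

Among the compounds with values here, one measured step bears on it, at the same place: fluoro in place of methoxy, a 1.8-fold lower number from compound 1 to compound 2 (0.26 log units; within the scatter). That step stays within the scatter. No measurement with bromo exists yet, so this single step is the whole basis for the expectation. No clear direction is expected in this assay, and the estimated step is a 1.2-fold lower number from compound 2 to compound 3 (0.07 log units; within the scatter), which means none beyond the scatter. For compound 3 the estimated value is 4500 nM, with an expected range from 2200 nM to 9500 nM.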

Compound 3, half-maximal inhibitory concentration: 57600 nM
Estimate against measurement, compound 3: 13-fold (1.11 log units) below, outside the stated range (above it).
By their numbers in this assay, from the lowest: compounds 2 and 1 (each within the scatter of the next); then compound 3.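

In this assay, this position on the six-membered aromatic ring now gives a step beyond the scatter, which the methoxy and fluoro pair did not: bromo in place of fluoro gives an 11-fold higher number from compound 2 to compound 3 (1.04 log units; beyond the scatter). Bromo in place of methoxy gives a 6.0-fold higher number from compound 1 to compound 3 (0.78 log units; beyond the scatter), so compound 3 is the weakest of the three, with both of its steps beyond the scatter, and the position is not indifferent to the group it carries. No supporting measurement bears on what lies behind this result.

As far as these compounds go, with only methoxy, fluoro and bromo at this position, it remains open whether the higher number belongs to bromo alone or extends to other groups, such as chloro, iodo, methyl or trifluoromethyl. Going by these compounds alone, it is also open how an amine or a carboxylic acid at the same place would read, and whether bromo would give a step of similar size on a core other than the one shared by compound 1, compound 2 and compound 3.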